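Working notes: from compound 3 to compound 4

The source may hold more compounds than are shown below. What is called first, only, known or untested is meant among the compounds shown, and "the series" means these compounds.

Measured so far:
compound 1 `N#Cc1ccccc1Cn1nc(-c2ccc(CO)o2)c2ccccc21` — 8700 nM
compound 2 `NS(=O)(=O)c1ccc(-c2nn(Cc3ccccc3F)c3ncccc23)o1` — 8000 nM
compound 3 `CCc1cnc(-c2nn(Cc3ccccc3F)c3ncccc23)nc1N` — 272000 nM

In a functional assay (aorta) with Oryctolagus cuniculus as the target (a higher number here means a weaker inhibitor, a lower number a stronger inhibitor), compound 3 gives the highest of the three numbers. Compound 1 and compound 2 both sit far lower, each beyond the scatter, so compound 3 is the weakest inhibitor of the set.

Compound 4 `Nc1nc(-c2nn(Cc3ccccc3F)c3ncccc23)ncc1F` differs from compound 3 in one place: fluoro in place of ethyl on an aromatic carbon. Among the compounds with values here, no measured pair shows this change, so the size of the step is not anchored by data. A small step is expected in this assay, most likely within the scatter and, if anything, toward a somewhat lower number. Compound 4 is estimated at 150000 nM, with a range of 40000 nM to 600000 nM. The expected step is a 1.8-fold lower number from compound 3 to compound 4 (0.26 log units; within the scatter).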

Compound 4, half-maximal inhibitory concentration: 478000 nM
For compound 4 the middle estimate is 3.2-fold (0.50 log units) below the measured one; the range from low to high includes it.
By their numbers in this assay, from the lowest: compounds 2 and 1 (each within the scatter of the next); then compounds 3 and 4 (each within the scatter of the next).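

In this assay, fluoro in place of ethyl on this aromatic carbon, ortho to an amino group, gives a 1.8-fold higher number from compound 3 to compound 4 (0.24 log units; within the scatter). At this position, the two groups therefore cannot be told apart in this read-out, even though one heavy atom replaces two. No supporting measurement bears on this result.

On these data alone, whether a longer chain, a carboxylic acid or a dimethylamino group on this carbon would move the number beyond the scatter remains open. The same question stands for hydrogen at this position.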